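Fluoro in Place of Hydrogen: Compound 3 to Compound 4

The source may report more compounds than this note shows. Statements on the series, on what has been measured and on what is new or still open speak of the compounds shown alone.

In a functional assay on A549 cells (Homo sapiens) for antiproliferative activity, read by MTT assay, with a stated time of 72 h (a lower number here means a stronger inhibitor, a higher number a weaker inhibitor), compound 1 `CNC(=O)c1cc(Oc2ccc(NC(=O)c3cc4cccnc4n(-c4ccc(Br)cc4)c3=O)cc2)ccn1` gives 1050 nM, and compound 2 `CNC(=O)c1cc(Oc2ccc(NC(=O)c3cc4cccnc4n(-c4ccc(Br)cc4F)c3=O)cc2)ccn1` gives 1420 nM. The change between them, (fluoro in place of hydrogen on an aromatic carbon), made a 1.4-fold higher number from compound 1 to compound 2 (0.13 log units; within the scatter). Compound 3 `CCCNC(=O)c1cc(Oc2ccc(NC(=O)c3cc4cccnc4n(-c4ccccc4)c3=O)cc2)ccn1` gives 95 nM in this assay; the difference between the core of compound 3 and that of compound 1 is not broken down here. Compound 4 `CCCNC(=O)c1cc(Oc2ccc(NC(=O)c3cc4cccnc4n(-c4ccccc4F)c3=O)cc2)ccn1` has not yet been measured. It differs from compound 3 by fluoro in place of hydrogen on an aromatic carbon, the same kind of change as in the earlier pair, though in compound 2 the place is also meta to a bromo group, and in compound 4 it is not. Because a 1.4-fold higher number from compound 1 to compound 2 (0.13 log units; within the scatter) lay within the scatter, the step of a 1.4-fold higher number from compound 3 to compound 4 (0.14 log units; within the scatter) is expected to be small as well. Compound 4 is therefore estimated at 130 nM, with a range from 60 nM to 300 nM.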

Compound 4, half-maximal inhibitory concentration: 150 nM
Estimate against measurement, compound 4: 1.2-fold (0.06 log units) below, within the range that was stated.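

In this assay, fluoro in place of hydrogen on an aromatic carbon gave a 1.6-fold higher number from compound 3 to compound 4 (0.20 log units; within the scatter), which leaves the two compounds indistinguishable in this assay. Set beside the earlier pair, the change gave steps of similar size on both cores: the same change on two cores in this assay, a 1.4-fold higher number (0.13 log units; within the scatter) from compound 1 to compound 2 and a 1.6-fold higher number (0.20 log units; within the scatter) from compound 3 to compound 4, 1.2-fold (0.07 log units) apart, within the scatter of two such steps. This shows that, on these two cores, the change made no difference beyond the scatter, but two pairs in one assay do not show that this would hold on other cores or at other ring carbons.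

The compounds shown leave open whether a chloro or methoxy group in the same place would behave like fluoro. They also leave open how much of the gap between compound 1 and compound 3 belongs to the bromo group and how much to the amide chain.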